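A Second Chloro Group on Compound 2

This account rests on a few compounds, and the source may have more. Where it says the series, first, only, none or still open, it means among the compounds named here.

Two allyloxy compounds have so far been read in a functional assay on IMR-32 cells (Homo sapiens) for cytotoxicity, read by sulforhodamine B assay, with a stated time of 48 h (a higher number here means a weaker inhibitor, a lower number a stronger inhibitor), as a pair. In this test compound 1 (`C=CCOc1ccc(F)cc1C(=O)c1cccnc1`) gives 91000 nM while compound 2 (`C=CCOc1c(Cl)cccc1C(=O)c1cccnc1`) gives 94000 nM as its reading. These two numbers lie within the scatter of each other, so compound 2 stands level with compound 1 and neither can be ranked above the other.

Compound 3 (`C=CCOc1c(Cl)cc(Cl)cc1C(=O)c1cccnc1`) departs from compound 2 in a single place. The difference is chloro in place of hydrogen on an aromatic carbon and it amounts to a chloro in place of hydrogen on an aromatic carbon, para to the allyloxy group and meta to the existing chloro group.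

Going by the values given here, no measured pair shows this change on its own, so the data offer no direct guide to its size. The two compounds in hand read alike despite carrying different halogens, with compound 2 at 94000 nM in the same range as compound 1. Only a small move in this assay is therefore expected, toward a lower number if there is any move beyond the scatter at all. The estimated change is a 1.3-fold lower number from compound 2 to compound 3 (0.13 log units; within the scatter) in this test. For compound 3 the expected value is 70000 nM with an estimated range from 30000 nM to 150000 nM in this test.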

Compound 3, half-maximal inhibitory concentration: 52000 nM
Compound 3: middle estimate off by 1.3-fold (0.13 log units), on the high side; the measured number falls inside the stated range.
By their numbers in this assay, from the lowest: compounds 3, 1 and 2 (each within the scatter of the next).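

Going by these compounds alone, the new result gives the first single-place change that can be read in this assay: chloro in place of hydrogen on this aromatic carbon, para to the allyloxy group and meta to the existing chloro group, comes to a 1.8-fold lower number from compound 2 to compound 3 (0.26 log units; within the scatter), which puts a measured size on a change that could earlier only be estimated. A second chloro group at this position, entering with no ring and no net charge, therefore leaves the reading within the scatter, and this single step cannot be taken as a real gain or loss in this test. Nothing measured alongside these readings bears on what lies behind this result.

The compounds shown leave open whether a different group at this same position, such as an amine, a methoxy group or a carboxylic acid, would give a step beyond the scatter. They also leave open whether a longer chain in place of the allyloxy group would shift the number in this assay, with the two chloro groups kept as they stand in compound 3.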